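Swapping the triazole chain for a bromophenyl group

The compounds below may be only part of what the source reports. "The series", "measured", "known", "first", "only" and "open" are said of these compounds alone.

Compound 1 `O=c1cc(Cn2cc(CCCCl)nn2)c2ccc(O)cc2o1`: 59800 nM
Compound 2 `CC(O)c1cn(Cc2cc(=O)oc3cc(O)ccc23)nn1`: > 100000 nM (a limit of the assay)
Compound 3 `O=c1cc(Cn2cc(CCc3ccccc3)nn2)c2ccc(O)cc2o1`: 84400 nM

In a functional assay on SW-620 cells (Homo sapiens) for inhibition, read by MTT assay, with a stated time of 72 h (on this read-out higher numbers stand for weaker inhibition and lower numbers for stronger inhibition), compound 1 gives 59800 nM. Compound 3 gives 84400 nM, and the gap between them lies within the scatter, so neither can be called the stronger inhibitor. Compound 2 reaches only a limit of the assay, > 100000 nM (the limit of > 100000 nM in this assay, at which 1 of the 3 values shown sits).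

Compound 4 `O=c1cc(Cn2cc(-c3ccc(Br)cc3)nn2)c2ccc(O)cc2o1` differs from compound 1 by 4-bromophenyl in place of 3-chloropropyl on an aromatic carbon. Two measured steps alter the same group on the same carbon: an at least 1.6-fold higher number from compound 1 to compound 2 (0.22 log units; that floor lies within the scatter) and a 1.4-fold higher number from compound 1 to compound 3 (0.15 log units; within the scatter). Neither moves beyond the scatter, so the bromophenyl group is also expected to leave the number close to that of compound 1. For compound 4 the expected step is a 1.1-fold lower number from compound 1 to compound 4 (0.04 log units; within the scatter). The estimate for compound 4 is 55000 nM, between 18000 nM and 160000 nM.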

Compound 4, half-maximal inhibitory concentration: 97700 nM
Compound 4: the middle estimate sits 1.8-fold (0.25 log units) below what was measured; measured number inside the range.
By their numbers in this assay, from the lowest: compounds 1, 3 and 4 (each within the scatter of the next). At a limit, above all of these: compound 2.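

Even a 4-bromophenyl group, which brings a six-membered aromatic ring of carbon only onto this carbon of the five-membered ring, leaves the number within the scatter of both compounds with a chain there: a 1.6-fold higher number from compound 1 to compound 4 (0.21 log units; within the scatter) and a 1.2-fold higher number from compound 3 to compound 4 (0.06 log units; within the scatter). So far, neither ring nor chain at this position separates these compounds. Compound 2 stands at a limit: the limit of > 100000 nM in this assay, at which 1 of the 4 values shown sits.

The step of an at least 1.0-fold lower number from compound 2 to compound 4 (0.01 log units; that floor lies within the scatter) gives only a floor and sets no order between the two.

As far as these compounds go, whether an amine or a carboxylic acid on this carbon would move the number beyond the scatter stays open.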